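A few compounds are considered here, and "the series" means these few. Any claim that something is new, unique, unknown or untested is made for them only; others in the source may bear on it.

Compound 1 `C#CC(=O)Nc1ccc(C#C)cc1` and compound 3 `C#CC(=O)Nc1ccccc1` share a core and differ only at one aromatic carbon. In a functional assay on B16 cells (Mus musculus) for cytotoxicity, read by MTT assay, with a stated time of 48 h (a lower number here means a stronger inhibitor, a higher number a weaker inhibitor), compound 1 gives 6300 nM, and in this assay compound 3 gives 6200 nM. The step of a 1.0-fold lower number from compound 1 to compound 3 (0.01 log units; within the scatter) corresponds to hydrogen in place of ethynyl on an aromatic carbon.

Compound 2 `C#Cc1ccc(NC(=O)c2cn(Cc3ccccc3)nn2)cc1` carries a different core; how that core differs from the core of compound 1 is not broken down here. In this assay compound 2 reaches only a limit of the assay, > 100000 nM; this is the value that sits at the limit of > 100000 nM in this assay, at which 1 of the 3 values shown sits.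

Compound 4 `O=C(Nc1ccccc1)c1cn(Cc2ccccc2)nn1` is not yet measured and follows from compound 2 by hydrogen in place of ethynyl on an aromatic carbon. Among the compounds with values here, this is the same kind of change as the one from compound 1 to compound 3, with a difference around the place: in compound 1 the ethynyl stands para to a group of 5 heavy atoms, in compound 2 para to a large group.

Because a 1.0-fold lower number from compound 1 to compound 3 (0.01 log units; within the scatter) lies within the scatter, the change is expected to move compound 4 by about a step that the limit leaves unreadable from compound 2 to compound 4 in this assay. Compound 4 is therefore expected to give roughly 150000 nM in this assay, estimated between 50000 nM and 500000 nM, most likely reported again as a limit rather than a number.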

Compound 4, half-maximal inhibitory concentration: 93000 nM
Compound 4: middle estimate off by 1.6-fold (0.21 log units), on the high side; the measured number falls inside the stated range.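

In this assay, hydrogen in place of ethynyl on the aromatic carbon gives an at least 1.0-fold lower number from compound 2 to compound 4 (0.03 log units; that floor lies within the scatter). Compound 2 stands at a limit of the assay, > 100000 nM, so this step is a floor and not a measured size. Neither core shows a step beyond the scatter for this change, which fits with it carrying over from one core to the other, but the true size of the step on the second core remains unknown and a difference between the two cores is not ruled out: the same change on two cores in this assay, a 1.0-fold lower number (0.01 log units; within the scatter) from compound 1 to compound 3 and an at least 1.0-fold lower number (0.03 log units; that floor lies within the scatter) from compound 2 to compound 4; the limit leaves it open whether they differ

The compounds shown carry only ethynyl or hydrogen at this place, so it remains open how an amine, a carboxylic acid or a longer chain there would read in this assay. Also open, from the compounds shown here alone, is whether the same change would stay within the scatter on a core beyond these two, and whether a number for compound 2 would show any step at all.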